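The source may hold more compounds than are shown below. What is called first, only, known or untested is meant among the compounds shown, and "the series" means these compounds.

Of the compounds shown here, three sharing one core have been measured in a functional assay on HEL cells (Homo sapiens); a higher number here means that more compound is tolerated, a lower number that less compound is tolerated. Compound 1 `CCOC(=O)NC(=O)NC1=CS(=O)(=O)O[C@@]12[C@@H](CO[Si](C)(C)C(C)(C)C)O[C@@H](n1cc(C)c(=O)n(C)c1=O)[C@@H]2O[Si](C)(C)C(C)(C)C` gives 14000 nM, the lowest of the three numbers. Compound 2 `COC(=O)CC(=O)NC1=CS(=O)(=O)O[C@@]12[C@@H](CO[Si](C)(C)C(C)(C)C)O[C@@H](n1cc(C)c(=O)n(C)c1=O)[C@@H]2O[Si](C)(C)C(C)(C)C` gives 29000 nM, and compound 3 `COC(=O)CCNC1=CS(=O)(=O)O[C@@]12[C@@H](CO[Si](C)(C)C(C)(C)C)O[C@@H](n1cc(C)c(=O)n(C)c1=O)[C@@H]2O[Si](C)(C)C(C)(C)C` gives 94000 nM. Both a 2.1-fold higher number from compound 1 to compound 2 (0.32 log units; beyond the scatter) and a 6.7-fold higher number from compound 1 to compound 3 (0.83 log units; beyond the scatter) move to higher numbers, and a 3.2-fold higher number from compound 2 to compound 3 (0.51 log units; beyond the scatter) is modest as well. Compound 4 `C=C(C)C(=O)NC(=O)NC1=CS(=O)(=O)O[C@@]12[C@@H](CO[Si](C)(C)C(C)(C)C)O[C@@H](n1cc(C)c(=O)n(C)c1=O)[C@@H]2O[Si](C)(C)C(C)(C)C` differs from compound 1 at a single place: 1-methylethenyl in place of ethoxy on a carbonyl carbon. Among the measured compounds shown here, no measured step swaps a group on this carbonyl carbon in just this way; the nearest comparison, a 2.1-fold higher number from compound 1 to compound 2 (0.32 log units; beyond the scatter), was small. The expected step is therefore a 1.2-fold lower number from compound 1 to compound 4 (0.07 log units; within the scatter), most plausibly within the scatter. Compound 4 is estimated at 12000 nM, with a range from 4000 nM to 36000 nM.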

Compound 4, half-maximal cytotoxic concentration: 1200 nM
Beside the measured number, compound 4's estimate is 10-fold (1.00 log units) above it; measured number below the stated range.
By their numbers in this assay, from the lowest: compound 4; then compound 1; then compound 2; then compound 3.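

At this carbonyl carbon, every earlier step was modest and moved to higher numbers, whereas putting 1-methylethenyl in place of ethoxy in this assay gives a large move the other way: a 12-fold lower number from compound 1 to compound 4 (1.07 log units; beyond the scatter). Against the other two compounds the drop is larger still, with a 24-fold lower number from compound 2 to compound 4 (1.38 log units; beyond the scatter) and a 78-fold lower number from compound 3 to compound 4 (1.89 log units; beyond the scatter), so compound 4 now marks the low end of the series. Nothing available explains this drop. A compound with isopropyl on this carbonyl carbon would show whether the double bond of 1-methylethenyl matters.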